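Chlorine for methoxy on the ester ring of a lactone core

This account rests on a few compounds, and the source may have more. Where it says the series, first, only, none or still open, it means among the compounds named here.

Compound 1 `C=C1C(=O)[C@@]23C(=O)OC[C@]4([C@@H](OC(C)=O)CCC(C)(C)[C@H]4C=O)[C@@H]2CC[C@H]1[C@H]3OC(=O)c1ccc(OC)cc1` is tested in a functional assay on K562 cells (Homo sapiens) for inhibition, read by MTT assay (a lower number here means a stronger inhibitor, a higher number a weaker inhibitor), where compound 1 gives 1920 nM. Of the three measured compounds, compound 1 has the highest number. Compound 2 `C=C1C(=O)[C@@]23C(=O)OC[C@]4([C@@H](OC(C)=O)CCC(C)(C)[C@H]4C=O)[C@@H]2CC[C@H]1[C@H]3OC(=O)c1ccc(C)cc1` gives 1310 nM, and the step from methoxy to methyl is a 1.5-fold lower number from compound 1 to compound 2 (0.17 log units; within the scatter). Compound 3 `C=C1C(=O)[C@@]23C(=O)OC[C@]4([C@@H](OC(C)=O)CCC(C)(C)[C@H]4C=O)[C@@H]2CC[C@H]1[C@H]3OC(=O)c1ccc(Cl)cc1` gives 870 nM, a step of a 2.2-fold lower number from compound 1 to compound 3 (0.34 log units; beyond the scatter); between compound 2 and compound 3 the step is a 1.5-fold lower number from compound 2 to compound 3 (0.18 log units; within the scatter).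

Compound 4 `C=C1C(=O)[C@@]23C(=O)OC[C@]4([C@@H](OC(C)=O)CCC(C)(C)[C@H]4C=O)[C@@H]2CC[C@H]1[C@H]3OC(=O)c1ccccc1Cl` differs from compound 1 in this way: 2-chlorophenyl in place of 4-methoxyphenyl on a carbonyl carbon. Among the compounds with values here, the one measured step that bears on it is the chloro-for-methoxy change from compound 1 to compound 3, because a 2.2-fold lower number from compound 1 to compound 3 (0.34 log units; beyond the scatter) shows a modest drop; still, 2-chlorophenyl is not the same group as the ring in compound 3, so the carry-over is uncertain. A small to modest lowering is therefore expected, a 1.7-fold lower number from compound 1 to compound 4 (0.24 log units; within the scatter), with the chance that it stays within the scatter. The estimate for compound 4 in this assay is 1100 nM, within 500 nM to 2400 nM.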

Compound 4, half-maximal inhibitory concentration: 390 nM
Beside the measured number, compound 4's estimate is 2.8-fold (0.45 log units) above it, and the stated range ends above it.
By their numbers in this assay, from the lowest: compound 4; then compounds 3, 2 and 1 (each within the scatter of the next, the first and the last beyond it).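

Moving the chlorine within the ring, with the same atoms in both compounds, gives a 2.2-fold lower number from compound 3 to compound 4 (0.35 log units; beyond the scatter) in this assay. At this position, then, where the chlorine sits on the ring matters, not only whether chlorine is present. Against the other two rings the gap is wider (a 4.9-fold lower number from compound 1 to compound 4 (0.69 log units; beyond the scatter) and a 3.4-fold lower number from compound 2 to compound 4 (0.53 log units; beyond the scatter)), so the 2-chlorophenyl ester gives the lowest number of the four, beyond the scatter from each of the others, and nothing shown here explains this difference.

From the compounds shown here alone, it remains open whether a methyl or methoxy group in the place the chlorine holds in the 2-chlorophenyl ring would lower the number in the same way. The effect of a bromine or an amine there, or of a ring carrying two chlorines, is also unknown.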